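Two triazole ethers at the assay ceiling and an aryl analogue

The source may report more compounds than this note shows. Statements on the series, on what has been measured and on what is new or still open speak of the compounds shown alone.

Measured so far:
Compound 1, `CCCCCCCCn1cc(COC2(C(F)(F)F)Oc3ccccc3C=C2C(=O)OCC)nn1` — in a functional assay on DU-145 cells (Homo sapiens) for inhibition, read by MTT assay, with a stated time of 24 h (on this read-out lower numbers stand for stronger inhibition and higher numbers for weaker inhibition), compound 1 gives > 150000 nM, a limit of the assay.
Compound 2, `CCOC(=O)C1=Cc2ccccc2OC1(OCc1cn(CC(=O)Nc2ccccc2Br)nn1)C(F)(F)F` — in this assay compound 2 gives > 150000 nM, also a limit of the assay.

For the measured compounds named here, compound 2 therefore stands not at a number but at the ceiling of what this assay could report, and the only measured step, a step that the two limits leave unreadable from compound 1 to compound 2, cannot be sized because both of its ends sit at that ceiling (the limit of > 150000 nM in this assay, at which 2 of the 2 values shown sit).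

Compound 3, `CCOC(=O)C1=Cc2ccccc2OC1(OCc1cn(-c2ccc(F)c([N+](=O)[O-])c2)nn1)C(F)(F)F`, differs from compound 2 in one place: 4-fluoro-3-nitrophenyl in place of ((2-bromophenyl)carbamoyl)methyl on an aromatic nitrogen. In words, 4-fluoro-3-nitrophenyl takes the place of ((2-bromophenyl)carbamoyl)methyl on an aromatic nitrogen. The measured step from compound 1 to compound 2 touches the same position but gives no readable size, so it offers no direction for this change either.

With both measured compounds at the limit, compound 3 is expected to land there as well, with real uncertainty. For compound 3 the estimate in this assay is 150000 nM, with a range from 30000 nM to 600000 nM. The expected step is a number no higher from compound 2 to compound 3 (the limit leaves the size open).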

Compound 3, half-maximal inhibitory concentration: 13200 nM
Beside the measured number, compound 3's estimate is 11-fold (1.06 log units) above it, outside the stated range (below it).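

The aromatic nitrogen of the five-membered ring turns out to be a place where a change can be read in this assay, which the earlier pair could not show. Putting 4-fluoro-3-nitrophenyl there in place of ((2-bromophenyl)carbamoyl)methyl gives an at least 11-fold lower number from compound 2 to compound 3 (1.05 log units; beyond the scatter), and putting it there in place of octyl gives an at least 11-fold lower number from compound 1 to compound 3 (1.05 log units; beyond the scatter), so two different starting groups lead to the same clear gain in inhibition, and in both the new group is an aromatic ring in place of a group attached through a saturated chain carbon. Both steps are only minimum sizes, because compound 1 and compound 2 each stand at a limit of the assay rather than at a true number: the limit of > 150000 nM in this assay, at which 2 of the 3 values shown sit.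

With only one aryl group at this position, the compounds shown cannot tell whether the aromatic ring itself, the fluorine or the nitro group accounts for the gain. A plain phenyl group would begin to separate these parts, and an amine in the place of the nitro group would test whether compound 3's reading of 13200 nM depends on that group.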